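Series notes: from compound 3 to compound 4

The source may report more compounds than this note shows. Statements on the series, on what has been measured and on what is new or still open speak of the compounds shown alone.

Measured compounds so far:
- Compound 1 `COc1ccc(-n2c(SCC(=O)c3ccc4ccccc4c3)nnc2-c2cc(OC)c(OC)c(OC)c2)cc1`; in a functional assay on HepG2 cells (Homo sapiens) for inhibition, read by MTT assay, with a stated time of 48 h (a higher number here means a weaker inhibitor, a lower number a stronger inhibitor), compound 1 gives only a limit of the assay, > 60000 nM.
- Compound 2 `CCOC(=O)CSc1nnc(-c2cc(OC)c(OC)c(OC)c2)n1-c1ccc(OC)cc1`; in this assay compound 2 likewise gives only a limit, > 60000 nM.
- Compound 3 `COc1ccc(-n2c(SCC(=O)Nc3ccc(Cl)cc3)nnc2-c2cc(OC)c(OC)c(OC)c2)cc1`; in this assay compound 3 also gives only a limit, > 60000 nM.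

Compound 3 therefore stands where the whole series stands so far, at the limit described by the limit of > 60000 nM in this assay, at which 3 of the 3 values shown sit. Every value is a limit. The three measured steps therefore cannot be sized: a step that the two limits leave unreadable from compound 1 to compound 2, a step that the two limits leave unreadable from compound 1 to compound 3 and a step that the two limits leave unreadable from compound 2 to compound 3 all remain unreadable. They also all concern the group on the carbonyl carbon, a different place from the change now considered.

Compound 4 `COc1cc(-c2nnc(SCC(=O)Nc3ccc(Cl)cc3)n2-c2ccc(N(C)C)cc2)cc(OC)c1OC` differs from compound 3 by dimethylamino in place of methoxy on an aromatic carbon. For the measured compounds named here, no measured step touches this position, and none of the measured steps has a readable size, so nothing supports expecting a move off the limit in this assay, in either direction, beyond the scatter. The step from compound 3 to compound 4 is estimated as a number no higher from compound 3 to compound 4 (the limit leaves the size open), essentially no readable change. Compound 4 is expected to give about 60000 nM, within a range from 20000 nM to 200000 nM, most probably reported again only as a limit.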

Compound 4, half-maximal inhibitory concentration: > 60000 nM
Compound 4: only a limit was reported (the forecaster's own chance of this, stated with the estimate: 80%); the middle value sits exactly at the limit.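

Compound 3 and compound 4 both give only a limit in this assay, so no size can be read for the step between them, and the series remains at a single limit: the limit of > 60000 nM in this assay, at which 4 of the 4 values shown sit.

The compounds shown leave open whether any change, on the carbonyl carbon or at the 4-methoxyphenyl group, can bring a value off this limit.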